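A few compounds are considered here, and "the series" means these few. Any claim that something is new, unique, unknown or untested is made for them only; others in the source may bear on it.

In a functional assay on Hep 3B2 cells (Homo sapiens) for antiproliferative activity, read by MTT assay, with a stated time of 24 h, tested at 0.01 ug/mL (on this read-out higher numbers stand for a stronger effect at the one concentration tested and lower numbers for a weaker effect), compound 1 `CCOc1ccc2nc(C(=O)Nc3c(F)cc(-c4cccc(F)c4)cc3F)c(C)c(O)c2c1` gives -0.5%, and compound 2 `Cc1c(C(=O)Nc2c(F)cc(-c3cccc(F)c3)cc2F)nc2ccc(OC(F)(F)F)cc2c1O` gives 0.32%. For the measured compounds named here, the one step known, a number 0.8 percentage points higher from compound 1 to compound 2 (within the scatter), changes the group on this same aromatic carbon and leaves the two values within the scatter of each other. Compound 3 `Cc1c(C(=O)Nc2c(F)cc(-c3cccc(F)c3)cc2F)nc2ccc(C(F)(F)F)cc2c1O` differs from compound 2 by trifluoromethyl in place of trifluoromethoxy on an aromatic carbon. Going by the values given here, no measured step covers this exact exchange, and the only step at this place was flat, so no change beyond the scatter is expected here. Compound 3 is therefore estimated at 0.3%, within -8% to 9%, an expected step of a number 0 percentage points lower from compound 2 to compound 3 (within the scatter).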

Compound 3, a percentage reported as inhibition, at one concentration (the size of the read-out at that concentration, not a potency): -0.33%
For compound 3 the middle estimate is 0.6 percentage points above the measured one; measured number inside the range.
By their numbers in this assay, from the lowest: compounds 1, 3 and 2 (each within the scatter of the next).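

With trifluoromethyl on this aromatic carbon, a third group joins ethoxy and trifluoromethoxy without separating from them in this assay: the data show a number 0.7 percentage points lower from compound 2 to compound 3 (within the scatter), and also a number 0.2 percentage points higher from compound 1 to compound 3 (within the scatter). The oxygen on the aromatic carbon, present in compound 1 and compound 2 and absent from compound 3, thus makes no difference beyond the scatter at this place. Nothing available explains this flat picture. From the compounds shown here alone, whether an amine or a carboxylic acid on this aromatic carbon would stand apart from these three groups remains open, as does whether the picture holds at other concentrations.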